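Ring size on the amide nitrogen and cytotoxicity

The compounds below may be only part of what the source reports. "The series", "measured", "known", "first", "only" and "open" are said of these compounds alone.

Compound 1, `CC(C)(C)C(=O)N(CCCCCCN1C[C@H](O)[C@@H](O)[C@H](O)[C@H]1CO)C1CCCCC1`, gives > 500000 nM in an ADME assay on MDBK cells (Bos taurus) for cytotoxicity, read by MTT assay (on this read-out higher numbers stand for lower toxicity in this test and lower numbers for higher toxicity in this test), and this value is a limit of the assay rather than a number. Compound 2, `CC(C)(C)C(=O)N(CCCCCCN1C[C@H](O)[C@@H](O)[C@H](O)[C@H]1CO)C1CCC1`, gives > 500000 nM in this assay, which is again a limit of the assay.

Compound 2 therefore stands at the limit, and the evidence the limit of > 500000 nM in this assay, at which 2 of the 2 values shown sit, shows that both measured values sit there. The step that the two limits leave unreadable from compound 1 to compound 2 is consequently unreadable: its size cannot be taken from two limits.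

Compound 3, `CC(C)(C)C(=O)N(CCCCCCN1C[C@H](O)[C@@H](O)[C@H](O)[C@H]1CO)C1CCCC1`, differs from compound 2 by cyclopentyl in place of cyclobutyl on an amide-type nitrogen. Among the measured compounds shown here, the only measured step that bears on this change is a step that the two limits leave unreadable from compound 1 to compound 2, and since it is unreadable no size or direction can be carried over from it. In this assay compound 3 is therefore expected to reach the same limit, without a step beyond the scatter. Compound 3 is estimated at 500000 nM, with a range from 250000 nM to 1000000 nM. The expected step of a number no higher from compound 2 to compound 3 (the limit leaves the size open) is thus within the scatter.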

Compound 3, half-maximal cytotoxic concentration: > 500000 nM
Compound 3 ended at the assay's limit (the forecaster's own chance of this, stated with the estimate: 85%); the middle value lies on the limit itself.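

Compound 3 also gives a limit of the assay rather than a number, so its steps from compound 1 and compound 2 cannot be read: the limit of > 500000 nM in this assay, at which 3 of the 3 values shown sit.

The compounds shown leave open whether compound 1, compound 2 and compound 3 differ at all in this assay, and at what concentration each would harm these cells.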